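Swapping the aryl substituent: from phenyl to formyl

The source may report more compounds than this note shows. Statements on the series, on what has been measured and on what is new or still open speak of the compounds shown alone.

Measured so far:
compound 1, `COc1ccc(-n2cc(COc3ccc(/C=C/C(C)=O)cc3OC)nn2)cc1`, 2010 nM
compound 2, `COc1cc(/C=C/C(C)=O)ccc1OCc1cn(-c2ccc([N+](=O)[O-])cc2)nn1`, 46700 nM
compound 3, `COc1cc(/C=C/C(C)=O)ccc1OCc1cn(-c2ccc(-c3ccccc3)cc2)nn1`, 56800 nM

All three compounds share the same core and differ only in the group on an aromatic carbon of the terminal ring. In a functional assay on PC-3 cells (Homo sapiens) for antiproliferative activity, read by MTT assay, with a stated time of 48 h (a lower number here means a stronger inhibitor, a higher number a weaker inhibitor), compound 3 gives the highest of the three numbers. Its nearest neighbour is compound 2, with a 1.2-fold higher number from compound 2 to compound 3 (0.09 log units; within the scatter), a gap within the scatter. Compound 1 lies far away: a 28-fold higher number from compound 1 to compound 3 (1.45 log units; beyond the scatter), and likewise a 23-fold higher number from compound 1 to compound 2 (1.37 log units; beyond the scatter).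

Compound 4, `COc1cc(/C=C/C(C)=O)ccc1OCc1cn(-c2ccc(C=O)cc2)nn1`, carries a change at that same place: formyl in place of phenyl on an aromatic carbon. Two of the measured steps replace the methoxy of compound 1 and are both large; the third, the swap between nitro and phenyl, lies within the scatter. The new step resembles that third one, in that it exchanges one non-methoxy group for another. Going by the values given here, no step away from compound 1 has yet given a lower number, so a return toward the value of compound 1 is not supported.

Compound 4 is therefore expected to stay close to compound 3, with at most a modest shift: a 1.9-fold lower number from compound 3 to compound 4 (0.28 log units; within the scatter) is the estimated step, giving an expected 30000 nM, within 8000 nM to 100000 nM.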

Compound 4, half-maximal inhibitory concentration: 80700 nM
For compound 4 the middle estimate is 2.7-fold (0.43 log units) below the measured one, within the range that was stated.
By their numbers in this assay, from the lowest: compound 1; then compounds 2, 3 and 4 (each within the scatter of the next).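

In this assay, replacing the ring-bearing phenyl with the much smaller formyl, which has only two heavy atoms and one hydrogen-bond acceptor, produces no readable change (a 1.4-fold higher number from compound 3 to compound 4 (0.15 log units; within the scatter)), and exchanging nitro for formyl gives the same outcome (a 1.7-fold higher number from compound 2 to compound 4 (0.24 log units; within the scatter)). At this place, para to a large group, phenyl, nitro and formyl therefore cannot be told apart, even though they differ in size and in whether they carry a ring. Methoxy alone stands apart among the four groups, and formyl gives a third large step away from it (a 40-fold higher number from compound 1 to compound 4 (1.60 log units; beyond the scatter)), though nothing available here explains this difference.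

The compounds shown leave open whether the much lower number of compound 1 belongs to methoxy alone or would also appear with a related group such as ethoxy, hydroxyl or an amine at the same place. They also leave open whether a carboxylic acid or a longer chain would fall with phenyl, nitro and formyl or nearer to methoxy.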